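Three Analogues Measured, a Fourth Awaits Its Number

A few compounds are considered here, and "the series" means these few. Any claim that something is new, unique, unknown or untested is made for them only; others in the source may bear on it.

Compound 1 `O=C(Nc1ccnnc1)c1cc(C(F)(F)F)ccc1OCc1ccccc1` gives 15.9 nM in an assay on Sf9 cells for inhibition of Leucine-rich repeat serine/threonine-protein kinase 2 (Homo sapiens), read by TR-FRET, with stated times of 30 min and 2 h; on this read-out higher numbers stand for weaker inhibition and lower numbers for stronger inhibition.
Compound 2 `CN1CCC(c2ccc(OCc3ccccc3)c(C(=O)Nc3ccnnc3)c2)CC1` gives 20 nM in this assay.
Compound 3 `C[C@@H]1CN(c2ccc(OCc3ccccc3)c(C(=O)Nc3ccnnc3)c2)C[C@H](C)O1` gives 20 nM in this assay.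

Compound 3 sits level with compound 2, shown by no change at the digits printed from compound 2 to compound 3 (within the scatter), and close to compound 1, shown by a 1.3-fold higher number from compound 1 to compound 3 (0.10 log units; within the scatter). Compound 4 `O=C(Nc1ccnnc1)c1cc(N2CCC(O)CC2)ccc1OCc1ccccc1` is not yet measured; it differs from compound 3 by 4-hydroxypiperidin-1-yl in place of 2,6-dimethylmorpholin-4-yl on an aromatic carbon. The two steps that touch the same aromatic carbon, a 1.3-fold higher number from compound 1 to compound 2 (0.10 log units; within the scatter) and a 1.3-fold higher number from compound 1 to compound 3 (0.10 log units; within the scatter), both stayed within the scatter, so this third exchange at that carbon is expected to do the same: no change at the digits printed from compound 3 to compound 4 (within the scatter) is the step expected in this assay. Compound 4 is therefore estimated at 20 nM, within 8 nM to 50 nM.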

Compound 4, half-maximal inhibitory concentration: 39.8 nM
Estimate against measurement, compound 4: 2.0-fold (0.30 log units) below; measured number inside the range.
By their numbers in this assay, from the lowest: compounds 1, 2, 3 and 4 (each within the scatter of the next, the first and the last beyond it).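

Among these compounds, at this aromatic carbon, para to a benzyloxy group, 4-hydroxypiperidin-1-yl, the only entering group here with a hydrogen-bond donor, gave a 2.0-fold higher number from compound 3 to compound 4 (0.30 log units; within the scatter) and a 2.0-fold higher number from compound 2 to compound 4 (0.30 log units; within the scatter) in this assay and so stayed inside the scatter against both ring-bearing groups. Among the compounds shown here, only the exchange for trifluoromethyl, with a 2.5-fold higher number from compound 1 to compound 4 (0.40 log units; beyond the scatter), passes the scatter, the first step at this carbon to do so, and it is modest. Nothing shown gives a reason for this step. Still open, going by these compounds, is whether a primary amine or a carboxylic acid at this carbon, or a methyl ether in place of the hydroxyl, would move the number further.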